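Swapping a Thiazole for a Methylpyrazole on an Inactive Core

This account rests on a few compounds, and the source may have more. Where it says the series, first, only, none or still open, it means among the compounds named here.

Compound 1 `c1cc(-c2nccs2)c2c(c1)C(c1ncc[nH]1)CC2` carries a 1,3-thiazol-2-yl group on the six-membered carbon ring of its fused two-ring core. In a functional assay on CHO cells for agonist activity at Alpha-1B adrenergic receptor (Homo sapiens), read by FLIPR and calcium flux (a higher number here means that more compound is needed for the effect, a lower number that less compound is needed), compound 1 gives > 10000 nM, which is a limit of the assay rather than a measured number. Its two close relatives behave alike. Compound 2 `Cc1ccc2c(c1NS(C)(=O)=O)CCC2c1ncc[nH]1` gives > 10000 nM, again only a limit. Compound 3 `Clc1ccc2c(c1-c1ccn[nH]1)CCC2c1ncc[nH]1` gives > 10000 nM, also a limit. Compound 1 therefore stands nowhere distinct: all values on hand sit at the limit of > 10000 nM in this assay, at which 3 of the 3 values shown sit, and none of the three compounds can be ranked against the others.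

Compound 4 `Cc1n[nH]cc1-c1cccc2c1CCC2c1ncc[nH]1` differs from compound 1 in one place: 3-methyl-1H-pyrazol-4-yl in place of 1,3-thiazol-2-yl on an aromatic carbon. For the measured compounds named here, no measured pair of compounds shows a change of this kind, so the size of the step cannot be read from the data and has to be estimated. Because compound 1 sits at the limit of > 10000 nM in this assay, at which 3 of the 3 values shown sit, compound 4 is expected to remain near that limit as well. The step from compound 1 to compound 4 is expected to be an at least 1.1-fold lower number from compound 1 to compound 4 (0.04 log units; that floor lies within the scatter), that is, no change beyond the usual scatter. Compound 4 is thus estimated at 9000 nM, with a plausible range from 2000 nM to 30000 nM, and most likely the assay will again report only a limit.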

Compound 4, half-maximal effective concentration: 902 nM
The estimate for compound 4 lay 10-fold (1.00 log units) above the measured number; the whole stated range lies above it.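

In this assay, replacing 1,3-thiazol-2-yl with 3-methyl-1H-pyrazol-4-yl on this aromatic carbon gives an at least 11-fold lower number from compound 1 to compound 4 (1.04 log units; beyond the scatter), so the group at this position can lift a compound clear of the assay's limit. The earlier compounds shown here could not show this, as none of them gave a number that could be compared: the limit of > 10000 nM in this assay, at which 3 of the 4 values shown sit. From the compounds shown here alone, the value of compound 1 is only a limit, so the step is a floor and its true size remains unknown.

The swap also changes several things at once: the incoming group has one more heavy atom, a methyl, a different arrangement of ring hetero atoms with nitrogen in place of sulfur, and a hydrogen-bond donor that 1,3-thiazol-2-yl lacks, and the compounds shown do not separate these changes. Still open, going by these compounds, is how the number would respond to other groups at this position, such as an ethyl in place of the methyl on the pyrazole, an amine on that ring, or a carboxylic acid.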